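This account rests on a few compounds, and the source may have more. Where it says the series, first, only, none or still open, it means among the compounds named here.

Measured compounds in this set:
- compound 1 `Cn1c(-c2ccc(C#N)cc2)cnc1NC(=O)c1ccc(F)cc1` in a toxicity assay on THP-1 cells (Homo sapiens) for inhibition (on this read-out lower numbers stand for higher toxicity in this test and higher numbers for lower toxicity in this test), gives > 50000 nM
- compound 2 `COc1ccc(-c2cnc(NC(=O)C3CCCCC3)n2C)cc1` gives > 100000 nM
- compound 3 `Cn1c(-c2ccccc2)cnc1NC(=O)c1cccc(Cl)c1` gives > 50000 nM

Each of these three values is a limit of the assay and not a number. For compound 2 the value > 100000 nM is a limit; it stands at the limit of > 100000 nM in this assay, at which 1 of the 3 values shown sits. The values of compound 1 and compound 3 sit at the limit of > 50000 nM in this assay, at which 2 of the 3 values shown sit. Among the compounds with values here, nothing in the set shows a numerical half-maximal cytotoxic concentration; every compound measured so far sits at a limit, so no ordering of the three is possible and no step between any two of them can be sized. Within the data shown here, no pair of measured compounds differing in a single place exists here.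

Compound 4 `COc1ccc(C(=O)Nc2ncc(-c3ccc(OC)cc3)n2C)cc1` differs from compound 2 by 4-methoxyphenyl in place of cyclohexyl on a carbonyl carbon. The 4-methoxyphenyl on the carbonyl carbon matches the aryl amides of compound 1 and compound 3, which also sit at a limit. With every neighbour at a limit, the expected step of a number no higher from compound 2 to compound 4 (the limit leaves the size open) is none beyond the scatter, and the most likely outcome for compound 4 in this assay is again a limit rather than a number. The estimate for compound 4 is 100000 nM, within 40000 nM to 300000 nM.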

Compound 4, half-maximal cytotoxic concentration: > 100000 nM
Compound 4 ended at the assay's limit (the forecaster's own chance of this, stated with the estimate: 80%); the middle value sits exactly at the limit.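

In this assay compound 4 gives > 100000 nM, a limit of the assay and not a number. Within the data shown here, compound 2 gives > 100000 nM, likewise a limit, so no step between compound 2 and compound 4 can be read. The compounds shown leave open where the half-maximal cytotoxic concentration of any of them actually lies.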